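The source may report more compounds than this note shows. Statements on the series, on what has been measured and on what is new or still open speak of the compounds shown alone.

Measured so far in an ADME assay on microsomes from liver (Canis lupus familiaris) for metabolic stability; on this read-out higher numbers stand for a longer-lived compound and lower numbers for a shorter-lived compound:

Compound 1 `FC(F)(F)c1ccc(NCCNc2ncc(-c3ncc[nH]3)c(-c3ccc(Cl)cc3Cl)n2)nc1`: > 0.5 h
Compound 2 `Clc1ccc(-c2nc(NCCNc3ccccn3)ncc2-c2ncc[nH]2)c(Cl)c1`: > 0.5 h
Compound 3 `Nc1nc(NCCNc2ncc(-c3ncc[nH]3)c(-c3ccccc3Br)n2)ccc1[N+](=O)[O-]`: > 0.5 h

Compound 3 stands at > 0.5 h, which is a limit and not a number. The other two compounds give no firmer footing, as all the readings sit together: the limit of > 0.5 h in this assay, at which 3 of the 3 values shown sit.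

Compound 4 `Nc1nc(NCCNc2ncc(-c3ncc[nH]3)c(-c3ccc(F)cc3Cl)n2)ccc1[N+](=O)[O-]` departs from compound 3 in one place, (2-chloro-4-fluorophenyl in place of 2-bromophenyl on an aromatic carbon). In words, 2-chloro-4-fluorophenyl takes the place of 2-bromophenyl on an aromatic carbon of the shared core, ortho to a 1H-imidazol-2-yl group.

Among the compounds with values here, only one measured step exists between compounds that differ in one place, a step that the two limits leave unreadable from compound 1 to compound 2. It swaps trifluoromethyl for hydrogen, which is a different change at a different place, and its size cannot be read. It therefore offers no size to carry over to the present change. The expectation rests on compound 3 and its limit of > 0.5 h, so no step beyond the usual scatter is expected in this assay, and no direction can be argued. The expected change, a step that the limit leaves unreadable from compound 3 to compound 4, is an estimate only. For compound 4 the estimated half-life is 0.7 h, with an expected range from 0.4 h to 1.5 h, and a reading at the same limit would be no surprise.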

Compound 4, half-life: > 0.5 h
Compound 4 gave a limit, no number; the forecaster's own chance of this, stated with the estimate: 70%; the middle value does not contradict the limit.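

In this assay compound 4 gives > 0.5 h, which is a limit and not a number. Compound 3 also stands at a limit, so no size can be read for the step between compound 3 and compound 4. The compounds shown leave open whether 2-chloro-4-fluorophenyl in place of 2-bromophenyl alters the half-life at all, and every reading offers only this: the limit of > 0.5 h in this assay, at which 4 of the 4 values shown sit.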